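Aryl swap on the pyrazole core: compound 1 to compound 4

The source may hold more compounds than are shown below. What is called first, only, known or untested is meant among the compounds shown, and "the series" means these compounds.

Measured so far, in a functional assay on BJAB cells (Homo sapiens) for antiproliferative activity, with a stated time of 4 days; on this read-out higher numbers stand for an effect only at larger amounts of compound and lower numbers for an effect already at smaller amounts:
- compound 1, `Cc1nn(-c2nc(-c3ccc(Cl)c(Cl)c3)c(SC(C)C)s2)c(C(=O)O)c1-c1cccc(Cl)c1C`, gives 5100 nM
- compound 2, `Cc1c(-c2cc(Cl)cc(Cl)c2)c(C(=O)O)nn1-c1nc(-c2cc(Cl)cc(Cl)c2)c(SC(C)C)s1`, gives 2000 nM
- compound 3, `Cc1c(-c2cc(Cl)cc(Cl)c2)c(C(=O)O)nn1-c1nc(-c2ccc3nccn3c2)c(SC(C)C)s1`, is reported as "not active" (no number reported), without a number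

Compound 1 carries the highest of the two numbers in this assay. Its nearest neighbour is compound 2, whose lower number sits beyond the usual scatter, so the two are distinguishable. Compound 3 contributes no number at all, only the note that it showed no activity.

Compound 4, `Cc1nn(-c2nc(-c3ccc(Cl)c(Cl)c3)c(SC(C)C)s2)c(C(=O)O)c1-c1ccccc1C(F)(F)F`, is the next entry. Relative to compound 1 the change is 2-(trifluoromethyl)phenyl in place of 3-chloro-2-methylphenyl on an aromatic carbon; the remainder of the molecule, including the carboxy group and the methyl group on the core, is kept.

Going by the values given here, no measured pair in this set differs in just this position, so there is no step to lean on. The working expectation is a step of no more than the scatter, in either direction, from compound 1 to compound 4, a 1.2-fold higher number from compound 1 to compound 4 (0.07 log units; within the scatter). Compound 4 is therefore estimated at 6000 nM in this assay, with a range from 2000 nM to 20000 nM.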

Compound 4, half-maximal effective concentration: 5200 nM
The estimate for compound 4 lay 1.2-fold (0.06 log units) above the measured number; measured number inside the range.
By their numbers in this assay, from the lowest: compound 2; then compounds 1 and 4 (each within the scatter of the next).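

In this assay, this aromatic carbon of the shared core takes 2-(trifluoromethyl)phenyl in place of 3-chloro-2-methylphenyl with a 1.0-fold higher number from compound 1 to compound 4 (0.01 log units; within the scatter) as the step, so the two aryl groups cannot be told apart on this read-out. Going by these compounds alone, this is the first single-place comparison in the set, and it shows that exchanging the chlorine and methyl substituents for a trifluoromethyl group on the six-membered aromatic ring leaves the number within the scatter. No measurement shown bears on why the two compounds read alike.

Still open, going by these compounds, is how this position responds to an aryl ring carrying an amine or a carboxylic acid, or to a pyridine ring in place of the carbon-only ring. Also open, on these data alone, is whether a much smaller group, such as a methyl group, would read the same here.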